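This account rests on a few compounds, and the source may have more. Where it says the series, first, only, none or still open, it means among the compounds named here.

Of the compounds shown here, three built on one shared core have been measured in an assay on Cortex for displacement of a labelled ligand from Voltage-dependent L-type calcium channel subunit alpha-1D (Rattus norvegicus); on this read-out lower numbers stand for stronger inhibition and higher numbers for weaker inhibition. Compound 1 `COC(=O)C1=C(C)N=C(C)/C(=C(/O)OC)C1c1cccc(OCCO[N+](=O)[O-])c1` gives 970 nM, compound 2 `COC(=O)C1=C(C)N=C(C)/C(=C(/O)OC)C1c1cccc(OCc2no[n+]([O-])c2C)c1` gives 820 nM, and compound 3 `COC(=O)C1=C(C)N=C(C)/C(=C(/O)OC)C1c1cccc(OCc2nonc2C(N)=O)c1` gives 5100 nM. Compound 3 thus stands highest of the three numbers: a 5.3-fold higher number from compound 1 to compound 3 (0.72 log units; beyond the scatter) and a 6.2-fold higher number from compound 2 to compound 3 (0.79 log units; beyond the scatter), both beyond the scatter, whereas a 1.2-fold lower number from compound 1 to compound 2 (0.07 log units; within the scatter) lies within it. Compound 4 `COC(=O)C1=C(C)N=C(C)/C(=C(/O)OC)C1c1cccc(OCc2nonc2C#N)c1` differs from compound 3 by cyano in place of carbamoyl on an aromatic carbon. Going by the values given here, no measured pair exchanges carbamoyl for cyano, so no step bears on this change directly; the two steps into compound 3 show only that the carbamoyl-bearing ring reads weaker than either alternative at the same position, which leaves the direction for compound 4 open. For compound 4 in this assay the expected step is a 2.0-fold lower number from compound 3 to compound 4 (0.31 log units; beyond the scatter), a small move that may well stay within the scatter given the absence of a direct precedent. Compound 4 is estimated at 2500 nM, with a range from 800 nM to 8000 nM.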

Compound 4, half-maximal inhibitory concentration: 590 nM
Compound 4: middle estimate off by 4.2-fold (0.63 log units), on the high side; the measured number lies below the stated range.
By their numbers in this assay, from the lowest: compounds 4, 2 and 1 (each within the scatter of the next); then compound 3.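

In this assay the exchange of carbamoyl for cyano on this aromatic carbon gives an 8.6-fold lower number from compound 3 to compound 4 (0.94 log units; beyond the scatter), which ties the weak reading of compound 3 to the carbamoyl group and not to the five-membered aromatic ring that carries it. With cyano in its place, the ring side chain reads level with both other side chains, as a 1.4-fold lower number from compound 2 to compound 4 (0.14 log units; within the scatter) and a 1.6-fold lower number from compound 1 to compound 4 (0.22 log units; within the scatter) show. Nothing measured here explains why the two groups differ so far.

The compounds shown leave open whether another group on this carbon, such as an amine or a carboxylic acid, would read with cyano or with carbamoyl. They also leave open whether the step from carbamoyl to cyano keeps its size on a longer chain linking the five-membered ring to the oxygen on the aromatic ring.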